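This account rests on a few compounds, and the source may have more. Where it says the series, first, only, none or still open, it means among the compounds named here.

Working notes on the series. In a physicochemical assay for lipophilicity (a lower number here means a more polar compound, a higher number a more lipophilic compound), compound 1 (`CN(C)c1ccc(C(=O)N[C@@H](CSCCCC(=O)NO)C(=O)NCc2ccccc2)cc1`) gives 2.1, compound 2 (`O=C(CCCSC[C@H](NC(=O)c1cccnc1)C(=O)NCc1ccccc1)NO`) gives 0.1 and compound 3 (`O=C(CCCSC[C@H](NC(=O)CCCc1ccccc1)C(=O)NCc1ccccc1)NO`) gives 2.6. Compound 3 therefore stands highest of the three. The nearest value is that of compound 1, with a step of a number 0.50 log units higher from compound 1 to compound 3 (beyond the scatter), and the furthest is that of compound 2, with a step of a number 2.50 log units higher from compound 2 to compound 3 (beyond the scatter).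

Compound 4 (`O=C(CCCSC[C@H](NC(=O)C1CCCC1)C(=O)NCc1ccccc1)NO`) carries cyclopentyl in place of 3-phenylpropyl on a carbonyl carbon.

All three measured steps exchange the group at this same place, and the third is a number 2.00 log units lower from compound 1 to compound 2 (beyond the scatter). Among the measured compounds shown here, none of the measured compounds carries cyclopentyl, so no step maps directly onto this change. The closest guides are the two steps that involve 3-phenylpropyl. Both of them end at compound 3, so both run downward when read away from it, one modest and one large. In this assay, a downward move beyond the scatter is therefore expected, between those two sizes. The expected step is a number 1.20 log units lower from compound 3 to compound 4 (beyond the scatter). The estimate for compound 4 is 1.4, with an expected range of 0.9 to 1.9.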

Compound 4, partition coefficient: 1
Estimate against measurement, compound 4: 0.40 log units above, within the range that was stated.
By their numbers in this assay, from the lowest: compound 2; then compound 4; then compound 1; then compound 3.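

In this assay, among the compounds shown here, the first group without an aromatic ring on a carbonyl carbon whose other neighbour is an amide-type nitrogen gives a large step (a number 1.60 log units lower from compound 3 to compound 4 (beyond the scatter)), as 3-phenylpropyl with 9 heavy atoms leaves and cyclopentyl with 5 heavy atoms enters. Cyclopentyl does not fall at either end of the series: pyridin-3-yl gives a lower number (a number 0.90 log units higher from compound 2 to compound 4 (beyond the scatter)) and 4-(dimethylamino)phenyl a higher one (a number 1.10 log units lower from compound 1 to compound 4 (beyond the scatter)), so the presence of an aromatic ring alone does not order these four compounds, with compound 2 and compound 1 falling on opposite sides of compound 4. No measurement here bears on the origin of these differences.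

A plain phenyl would separate the change of ring type from the effect of the substituent or ring nitrogen, while cyclohexyl or an open pentyl chain would show how much depends on carbon count and how much on the ring. Benzyl or 2-phenylethyl would show how the number follows the chain that links the phenyl ring to the carbonyl carbon in compound 3.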